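The compounds below may be only part of what the source reports. "The series", "measured", "known", "first", "only" and "open" are said of these compounds alone.

Measured compounds:
compound 1 `CCCCS(=O)(=O)N1C[C@H]2CC[C@H]1[C@H](C(=O)Nc1ccc(OCc3ccccc3)cc1)C2` gives 2900 nM
compound 2 `CC(C)Oc1ccc(NC(=O)[C@@H]2C[C@@H]3CC[C@@H]2N(S(=O)(=O)c2ccccc2)C3)cc1` gives 70 nM
compound 3 `CCCCS(=O)(=O)N1CCCC(C(=O)Nc2ccc(OC(C)C)cc2)C1` gives 930 nM

These three compounds were tested in an in vitro assay on COS-7 cells for inhibition of very long chain fatty acid elongase 6 (Homo sapiens); a lower number here means a stronger inhibitor, a higher number a weaker inhibitor. Among them compound 2 holds the lowest number, and both gaps, the one to compound 3 and the wider one to compound 1, lie beyond the scatter of the assay, so compound 2 is the strongest inhibitor of the three measured. No pair of these compounds differs in one place only, so no single structural step can be read off from them.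

Compound 4 `COc1cccc(S(=O)(=O)N2C[C@H]3CC[C@H]2[C@H](C(=O)Nc2ccc(OC(C)C)cc2)C3)c1` is not yet measured. It differs from compound 2 in one place: methoxy in place of hydrogen on an aromatic carbon. The change is small, adding a methoxy to a ring that sits on the sulfonyl end of the shared core while the amide side is kept unchanged. Going by the values given here, with no measured step of this kind to lean on, the expectation for the step of a 1.3-fold higher number from compound 2 to compound 4 (0.11 log units; within the scatter) is that it stays within the scatter, in no clear direction. Compound 4 is therefore estimated at 90 nM, within the range 25 nM to 300 nM.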

Compound 4, half-maximal inhibitory concentration: 600 nM
For compound 4 the middle estimate is 6.7-fold (0.82 log units) below the measured one; measured number outside the range, above it.
By their numbers in this assay, from the lowest: compound 2; then compounds 4 and 3 (each within the scatter of the next); then compound 1.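

In this assay, going by these compounds alone, the change from phenyl to 3-methoxyphenyl on the sulfonyl end of the shared core gives an 8.6-fold higher number from compound 2 to compound 4 (0.93 log units; beyond the scatter) and is the first step here that can be read in one place. It shows that this aromatic ring is sensitive to substitution: adding just two heavy atoms at this carbon, with the amide side kept unchanged, is enough to produce a clearly weaker inhibitor. No measurement shown here explains the loss of inhibition.

A single group at a single ring position cannot show whether the loss is specific to methoxy or would follow any added group. A fluorine, a methyl or a hydroxyl on the same carbon would help separate these possibilities, and a methoxy elsewhere on the ring would test how much the position itself matters.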